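The compounds below may be only part of what the source reports. "The series", "measured", "known", "first", "only" and "open" are said of these compounds alone.

Compound 1, with the structure `Cc1nc(C(=O)N2CC3(CC3)C[C@H]2CNc2ncc(Cl)cn2)c(-c2ccccc2)s1`, was tested in a functional assay on CHO cells for antagonist activity at Orexin/Hypocretin receptor type 1 (Homo sapiens), read by FLIPR and calcium flux (a lower number here means a less potent compound, a higher number a more potent compound, by a factor of ten per unit of this negative logarithm), where compound 1 gives 6.8. Among the two numbers in hand this is the higher one, but only by a margin that means nothing: compound 2, with the structure `O=C(c1nc(C(F)(F)F)ccc1-c1ncccn1)N1CC2(CC2)C[C@H]1CNc1ccc(C(F)(F)F)cn1`, gives 6.7 in this assay, and the gap between the two lies within the usual scatter of repeated measurements, so neither can be called the more potent. Going by the values given here, no two measured compounds differ from each other in just one place, so no single structural change has yet been put to the test here.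

Compound 3, with the structure `Cc1nc(C(=O)N2CC3(CC3)C[C@H]2CNc2ccc(Cl)cn2)c(-c2ccccc2)s1`, is the untested compound. It differs from compound 1 in a single spot: 5-chloropyridin-2-yl in place of 5-chloropyrimidin-2-yl on an amine nitrogen. One six-membered aromatic ring stands in for another of the same size, and everything else in the molecule is unchanged.

Among the compounds with values here, with no measured step to lean on, the change is expected to be small, with the step from compound 1 to compound 3 estimated at no change at the digits printed from compound 1 to compound 3 (within the scatter), which is no more than the scatter in either direction. Compound 3 is therefore expected to give 6.8 in this assay, with a likely range from 6.2 to 7.4.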

Compound 3, negative logarithm of the antagonist equilibrium constant: 8.3
For compound 3 the middle estimate is 1.50 log units below the measured one; measured number outside the range, above it.
By their numbers in this assay, from the lowest: compounds 2 and 1 (each within the scatter of the next); then compound 3.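

Going by these compounds alone, this is the first single change to be tested here, and the effect is large: in this assay, the result is a number 1.50 log units higher from compound 1 to compound 3 (beyond the scatter). On paper the swap looks slight, since 5-chloropyridin-2-yl and 5-chloropyrimidin-2-yl are each a six-membered aromatic ring with 7 heavy atoms, and the entering ring differs by holding 1 hetero atom rather than 2, so the potency at this place on the amine nitrogen proves highly sensitive to the make-up of the ring. Nothing measured here accounts for the gain, so its cause remains unknown.

Within the data shown here, the swap has been seen only on the core of compound 1, so it remains open whether it would bring a similar gain with a different group on the amide carbonyl. Also open, as far as these compounds go, is how potency would respond to a chlorophenyl ring, which carries no ring nitrogen at all, or to a nitrile in place of the chlorine on the pyridine ring.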